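Nitrile in Place of Methoxy: Expected Shift in Potency

A few compounds are considered here, and "the series" means these few. Any claim that something is new, unique, unknown or untested is made for them only; others in the source may bear on it.

Of the compounds shown here, two built on a shared core have been measured in a functional assay on HepG2 cells (Homo sapiens) for antiproliferative activity, read by MTT assay, with a stated time of 48 h; a higher number here means a weaker inhibitor, a lower number a stronger inhibitor. Compound 1 `COc1ccc(-c2ccc3c(c2)C(=O)C(=O)N3Cc2ccc(Cl)cc2)cc1` gives 250 nM in this assay. Compound 2 `COc1ccc(CN2C(=O)C(=O)c3cc(-c4cccc(OC)c4)ccc32)cc1` gives 1890 nM in this assay, the higher of the two numbers; the gap between them lies beyond the usual scatter, so compound 1 stands as the stronger inhibitor of the pair. Compound 1 and compound 2 differ in more than one place. For the measured compounds named here, no single step between them can be read off.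

Compound 3 `COc1ccc(CN2C(=O)C(=O)c3cc(-c4ccc(C#N)cc4)ccc32)cc1` has not yet been measured. It differs from compound 2 at one site: 4-cyanophenyl in place of 3-methoxyphenyl on an aromatic carbon. Going by the values given here, with no comparable step among the measured compounds, the direction of the change remains open; a step of modest size, possibly toward a lower number, is expected, a 1.9-fold lower number from compound 2 to compound 3 (0.28 log units; within the scatter). Compound 3 is expected to give about 1000 nM in this assay, with a range from 300 nM to 3500 nM.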

Compound 3, half-maximal inhibitory concentration: 890 nM
Compound 3: middle estimate off by 1.1-fold (0.05 log units), on the high side; low and high end bracket the measured number.
By their numbers in this assay, from the lowest: compound 1; then compound 3; then compound 2.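

In this assay, for the compounds shown here, 4-cyanophenyl in place of 3-methoxyphenyl gives a 2.1-fold lower number from compound 2 to compound 3 (0.33 log units; beyond the scatter) and so provides the first single-site step on this aromatic carbon, a modest one that lies beyond the scatter. The two groups have equal counts of heavy atoms and hydrogen-bond acceptors, but they differ both in the substituent and in its place on the ring, so this one step cannot assign the change to either. No measured property of these groups bears on why the number moved.

Still open, on these data alone, is whether 3-cyanophenyl, or an amine or a carboxylic acid on the same ring, would move the number further. Compound 1 differs from compound 2 and compound 3 in more than one place, so its standing cannot be split into single changes.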